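Dichlorophenyl sulfonamide: expected cytotoxicity on human kidney cells

This account rests on a few compounds, and the source may have more. Where it says the series, first, only, none or still open, it means among the compounds named here.

Measured so far:
- compound 1, `Cc1ccc(S(=O)(=O)Nc2ccc(-c3nc4ccccc4o3)cc2)cc1`: 88000 nM
- compound 2, `Cc1ccc(S(=O)(=O)Nc2ccc3oc(-c4ccccc4)nc3c2)cc1`: 75000 nM
- compound 3, `O=S(=O)(Nc1ccc(-c2nc3ccccc3o2)cc1)c1ccc(C(F)(F)F)cc1`: 94000 nM

In an ADME assay on HEK293 cells (Homo sapiens) for cytotoxicity, read by resazurin assay, with a stated time of 48 h (on this read-out higher numbers stand for lower toxicity in this test and lower numbers for higher toxicity in this test), compound 1 gives 88000 nM. Compound 3 sits nearest to it, a 1.1-fold higher number from compound 1 to compound 3 (0.03 log units; within the scatter), and the value of compound 2 also lies within the scatter of compound 1, so the three numbers cannot be told apart.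

Compound 4, `O=S(=O)(Nc1ccc(-c2nc3ccccc3o2)cc1)c1ccc(Cl)c(Cl)c1`, has not yet been measured. It differs from compound 1 in one place: 3,4-dichlorophenyl in place of 4-methylphenyl on a sulfonyl sulfur. Among the measured compounds shown here, the only measured step that touches the same part of the molecule is the one from compound 1 to compound 3, where a trifluoromethyl took the place of a methyl on an aromatic carbon, and that step stayed within the scatter. Nothing measured here points to a change in this assay beyond the scatter for compound 4, so the expected step is a 1.1-fold lower number from compound 1 to compound 4 (0.04 log units; within the scatter). Compound 4 is therefore estimated at 80000 nM, with a range from 40000 nM to 160000 nM.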

Compound 4, half-maximal cytotoxic concentration: > 100000 nM
Compound 4 ended at the assay's limit; the forecaster's own chance of this, stated with the estimate: 15%; middle value at least 1.2-fold (0.09 log units) away from the limit.
By their numbers in this assay, from the lowest: compounds 2, 1 and 3 (each within the scatter of the next). At a limit, above all of these: compound 4.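

Compound 4 gives > 100000 nM in this assay, which is a limit of the assay and not a number. The step reads an at least 1.1-fold higher number from compound 1 to compound 4 (0.05 log units; that floor lies within the scatter), so a second replacement of 4-methylphenyl on a sulfonyl sulfur, this time by a group with two chlorine atoms, shows no sign of higher toxicity in this test. Its floor alone cannot separate compound 4 from compound 1, but compound 4 is the only compound shown that reaches the limit: the limit of > 100000 nM in this assay, at which 1 of the 4 values shown sits.

Going by these compounds, how far compound 4 truly lies from compound 1 remains open, as a limit gives no exact number to compare. Also open, on these data alone, is whether a phenyl carrying an amine or a carboxylic acid, in place of 4-methylphenyl on a sulfonyl sulfur, would give a clearly lower number in this assay.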